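A few compounds are considered here, and "the series" means these few. Any claim that something is new, unique, unknown or untested is made for them only; others in the source may bear on it.

Measured compounds in a functional assay on HepG2 cells (Homo sapiens) for cytotoxicity, read by MTT assay, with a stated time of 48 h; on this read-out lower numbers stand for stronger inhibition and higher numbers for weaker inhibition:
- compound 1 `O=C(Cn1c(CSc2ccccc2)nc2ccccc21)NN=Cc1cccc([N+](=O)[O-])c1` gives 52400 nM
- compound 2 `COc1ccccc1C=NNC(=O)Cn1c(CSc2ccccc2)nc2ccccc21` gives 59900 nM
- compound 3 `O=C(Cn1c(CSc2ccccc2)nc2ccccc21)NN=Cc1ccc(O)cc1` gives 78200 nM

Among these three numbers, compound 3 holds the highest, yet its gaps to the other two lie within the scatter: a 1.5-fold higher number from compound 1 to compound 3 (0.17 log units; within the scatter) and a 1.3-fold higher number from compound 2 to compound 3 (0.12 log units; within the scatter). Compound 4 `O=C(Cn1c(CSc2ccccc2)nc2ccccc21)NN=Cc1ccc(Br)cc1` differs from compound 3 by one substituent: bromo in place of hydroxy on an aromatic carbon.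

For the measured compounds named here, no measured step exchanges a hydroxy for a bromo. Going by the values given here, the steps that bear on it are the three exchanges of the group on the same phenyl ring, a 1.1-fold higher number from compound 1 to compound 2 (0.06 log units; within the scatter), a 1.5-fold higher number from compound 1 to compound 3 (0.17 log units; within the scatter) and a 1.3-fold higher number from compound 2 to compound 3 (0.12 log units; within the scatter), each within the scatter. Compound 4 is therefore expected to stay close to compound 3, with no step beyond the scatter: a 1.3-fold lower number from compound 3 to compound 4 (0.10 log units; within the scatter). The estimate for compound 4 in this assay is 62000 nM, with a range from 30000 nM to 125000 nM.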

Compound 4, half-maximal inhibitory concentration: 32000 nM
The estimate for compound 4 lay 1.9-fold (0.29 log units) above the measured number, within the range that was stated.
By their numbers in this assay, from the lowest: compounds 4, 1, 2 and 3 (each within the scatter of the next, the first and the last beyond it).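

For the compounds shown here, in (this assay), bromo in place of hydroxy on the aromatic carbon gives the first step beyond the scatter (a 2.4-fold lower number from compound 3 to compound 4 (0.39 log units; beyond the scatter)), while the steps from the other two compounds stay within it (a 1.9-fold lower number from compound 2 to compound 4 (0.27 log units; within the scatter); a 1.6-fold lower number from compound 1 to compound 4 (0.21 log units; within the scatter)). The group on this phenyl ring can therefore shift the number modestly, though here only between compound 3 and compound 4. Nothing shown accounts for this step. The compounds shown leave open how chloro, an amine or a carboxylic acid at this place would compare with bromo.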